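Removing one chloro from the core of compound 3

The source may hold more compounds than are shown below. What is called first, only, known or untested is meant among the compounds shown, and "the series" means these compounds.

Three compounds have so far been measured in a functional assay on A498 cells (Homo sapiens) for cytotoxicity, read by sulforhodamine B assay, with a stated time of 48 h; a lower number here means a stronger inhibitor of growth, a higher number a weaker inhibitor of growth:

compound 1, `Nc1nc(Cl)c2ncn(Cc3ccccc3CCl)c2n1`: 44700 nM
compound 2, `Nc1nc(Cl)c2ncn(Cc3ccc(CCl)cc3)c2n1`: 85100 nM
compound 3, `ClCc1ccccc1Cn1cnc2nc(Cl)nc(Cl)c21`: 5880 nM

Compound 3 has the lowest number of the three, and its gaps to compound 1 and to compound 2 both lie beyond the usual scatter of this assay, so it is the strongest inhibitor of growth among them. Compound 1 and compound 2 differ from compound 3 in more than one place, so their numbers tell where they stand but not what any single change does.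

Compound 4, `ClCc1ccccc1Cn1cnc2ncnc(Cl)c21`, has not yet been measured. It differs from compound 3 in one place: hydrogen in place of chloro on an aromatic carbon. For the measured compounds named here, no pair of measured compounds differing in only one place has been recorded, so no measured step supports a forecast. Going by the values given here, the only hint is that compound 1 and compound 2 do not carry chloro at that place and give the higher numbers: compound 1 gives 44700 nM and compound 2 gives 85100 nM. Compound 4 is therefore expected to be a weaker inhibitor of growth than compound 3, by a step of about a 2.6-fold higher number from compound 3 to compound 4 (0.41 log units; beyond the scatter). Compound 4 is estimated at 15000 nM, with a likely range from 5000 nM to 45000 nM.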

Compound 4, concentration for total growth inhibition: 33100 nM
The estimate for compound 4 lay 2.2-fold (0.34 log units) below the measured number; the range from low to high includes it.
By their numbers in this assay, from the lowest: compound 3; then compounds 4, 1 and 2 (each within the scatter of the next, the first and the last beyond it).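

In this assay, for the compounds shown here, this is the first step between measured compounds that differ in one place, so the effect of this chloro can now be read on its own. Hydrogen in place of chloro on the aromatic carbon between two ring nitrogen atoms gives a 5.6-fold higher number from compound 3 to compound 4 (0.75 log units; beyond the scatter), so in this pair the chloro at this position goes with stronger inhibition of growth. No measurement is available that explains why the number rises.

From the compounds shown here alone, whether another group on this carbon, such as bromo, methyl or methoxy, would give a number nearer that of compound 3 or that of compound 4 remains open. Going by these compounds, it is also open whether the same change would have a step of similar size with the chloromethyl group placed elsewhere on the benzene ring.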